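The source may report more compounds than this note shows. Statements on the series, on what has been measured and on what is new or still open speak of the compounds shown alone.

Measured so far in a functional assay on C6 cells (Rattus norvegicus) for cytotoxicity, read by MTT assay, with a stated time of 24 h, tested at 100 ug/mL; on this read-out lower numbers stand for a stronger effect and higher numbers for a weaker effect at the one concentration tested:
- compound 1 `Cc1ccc(-c2cs/c(=N/NC(=O)CSc3nncn3C)n2-c2ccccc2)cc1` gives 39.6%
- compound 2 `Cn1cnnc1SCC(=O)N/N=c1/scc(-c2ccc(C#N)cc2)n1-c1ccccc1` gives 55.2%
- compound 3 `Cn1cnnc1SCC(=O)N/N=c1/scc(-c2ccccc2)n1-c1ccccc1` gives 38.6%

Compound 1 stands second highest of the three numbers. Its nearest neighbour is compound 3, reached by a number 1 percentage points lower from compound 1 to compound 3 (within the scatter), a step within the scatter. The furthest is compound 2, reached by a number 15.6 percentage points higher from compound 1 to compound 2 (beyond the scatter), a modest step beyond the scatter. The third pair gives a number 16.6 percentage points lower from compound 2 to compound 3 (beyond the scatter). All three measured steps sit at one aromatic carbon of the aryl group; none of them touches the sulfur-linked heteroaryl.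

Compound 4 `Cc1ccc(-c2cs/c(=N/NC(=O)CSc3ncccn3)n2-c2ccccc2)cc1` differs from compound 1 by pyrimidin-2-yl in place of 4-methyl-4H-1,2,4-triazol-3-yl on a sulfur. For the measured compounds named here, no measured step bears on this part of the core, so nothing here argues for a shift in either direction, and the only nearby evidence, compound 1 against compound 3 in this assay, shows how small a change can be. The expected step is therefore none beyond the scatter, with a wide range.

Compound 4 is estimated at 41% in this assay, between 24% and 60%. The expected step is a number 1.4 percentage points higher from compound 1 to compound 4 (within the scatter).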

Compound 4, a percentage reported as activity, at one concentration (the size of the read-out at that concentration, not a potency): 45.9%
Beside the measured number, compound 4's estimate is 4.9 percentage points below it, within the range that was stated.
By their numbers in this assay, from the lowest: compounds 3, 1, 4 and 2 (each within the scatter of the next, the first and the last beyond it).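

In this assay, the exchange of 4-methyl-4H-1,2,4-triazol-3-yl for pyrimidin-2-yl on a sulfur gives a number 6.3 percentage points higher from compound 1 to compound 4 (within the scatter). For the compounds shown here, this is the first reading at the sulfur-linked heteroaryl: on the core of compound 1, a five-membered aromatic ring with 3 hetero atoms gives way to a six-membered one with 2 hetero atoms, with no difference that can be told from the scatter at the one concentration tested. Nothing available explains this outcome or ties it to either ring.

Open, from the compounds shown here alone, is whether a group other than an aromatic ring on that sulfur, such as a plain alkyl chain or a carboxylic acid, would stay within the scatter too. Also open, going by these compounds, is whether pyrimidin-2-yl reads the same when a nitrile replaces the methyl on the aromatic carbon.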